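A few compounds are considered here, and "the series" means these few. Any claim that something is new, unique, unknown or untested is made for them only; others in the source may bear on it.

Of the compounds shown here, three sharing one core have been measured in an ADME assay on MT4 cells (Homo sapiens) for cytotoxicity, read by MTT assay; a higher number here means that more compound is tolerated, a lower number that less compound is tolerated. Compound 1 `O=C1c2ccccc2C(=O)N1CCOC(=S)N(C(=O)c1ccc([N+](=O)[O-])cc1)c1ccc(Cl)cc1` gives > 100000 nM, which is a limit of the assay and not a number. Compound 2 `O=C1c2ccccc2C(=O)N1CCOC(=S)N(C(=O)c1cccc(Cl)c1Cl)c1ccc(Cl)cc1` gives 54000 nM. Compound 3 `O=C1c2ccccc2C(=O)N1CCOC(=S)N(C(=O)c1ccc(Cl)cc1Cl)c1ccc(Cl)cc1`, which carries a 2,4-dichlorophenyl, gives 18000 nM, the lowest of the two true numbers, and its nearest neighbour is compound 2, with a 3.0-fold lower number from compound 2 to compound 3 (0.48 log units; beyond the scatter).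

Compound 4 `O=C1c2ccccc2C(=O)N1CCOC(=S)N(C(=O)c1ccc([N+](=O)[O-])cc1Cl)c1ccc(Cl)cc1` differs from compound 3 in one place: nitro in place of chloro on an aromatic carbon. This puts nitro in place of chloro on an aromatic carbon, giving a 2-chloro-4-nitrophenyl.

The closest guide is compound 1, which also holds a nitro group, and an at least 5.5-fold lower number from compound 1 to compound 3 (0.74 log units; beyond the scatter) shows that its replacement by the dichlorinated ring lowers the number. Run backwards, that step suggests a rise on going to compound 4. However, compound 4 keeps one chloro, and an at least 1.8-fold lower number from compound 1 to compound 2 (0.26 log units; that floor lies within the scatter) is a smaller floor, so only part of that rise seems likely.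

The expected change is a 2.2-fold higher number from compound 3 to compound 4 (0.35 log units; beyond the scatter), towards more compound tolerated. For compound 4, the estimated value is 40000 nM, with an expected range from 15000 nM to 100000 nM.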

Compound 4, half-maximal cytotoxic concentration: 19000 nM
Beside the measured number, compound 4's estimate is 2.1-fold (0.32 log units) above it; the range from low to high includes it.
By their numbers in this assay, from the lowest: compounds 3 and 4 (each within the scatter of the next); then compound 2. At a limit, above all of these: compound 1.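

In this assay, nitro and chloro on the aromatic carbon para to a large group cannot be told apart once the other chloro of the 2-chloro-4-nitrophenyl is present: a 1.1-fold higher number from compound 3 to compound 4 (0.02 log units; within the scatter). Compound 4 keeps the nitro group of compound 1, yet chloro in place of hydrogen on an aromatic carbon gives an at least 5.2-fold lower number from compound 1 to compound 4 (0.72 log units; beyond the scatter), so among these compounds a nitro group does not by itself go with the highest tolerated amount. The 2,3-dichlorophenyl of compound 2 stays apart from this new ring too, with a 2.8-fold lower number from compound 2 to compound 4 (0.45 log units; beyond the scatter).

Going by these compounds, compound 1 gives > 100000 nM, which is a limit of the assay and not a number, so the full size of its step stays open: the limit of > 100000 nM in this assay, at which 1 of the 4 values shown sits. Also open is how an amine or a carboxylic acid at this ring position would compare with nitro and chloro.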